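Changing the Group on the Sulfonyl Sulfur

The source may report more compounds than this note shows. Statements on the series, on what has been measured and on what is new or still open speak of the compounds shown alone.

In a functional assay on DU-145 cells (Homo sapiens) for inhibition, read by trypan blue exclusion, with a stated time of 72 h (a higher number here means a weaker inhibitor, a lower number a stronger inhibitor), compound 1 `Cn1c(=O)c(S(=O)(=O)Cc2ccc(F)cc2)cc2cnc(Nc3ccc4[nH]ccc4c3)nc21` gives 30000 nM and compound 2 `Cn1c(=O)c(S(=O)(=O)Nc2ccc(F)cc2)cc2cnc(Nc3ccc4[nH]ccc4c3)nc21` gives 5000 nM, so compound 2 holds the lower, stronger number of the pair. Among the measured compounds shown here, only one measured step bears on the next change: a 6.0-fold lower number from compound 1 to compound 2 (0.78 log units; beyond the scatter). This modest step, beyond the scatter, put (4-fluorophenyl)amino in place of 4-fluorobenzyl on a sulfonyl sulfur. Compound 3 `Cc1ccc(S(=O)(=O)c2cc3cnc(Nc4ccc5[nH]ccc5c4)nc3n(C)c2=O)cc1`, not yet measured, changes that same place: 4-methylphenyl in place of (4-fluorophenyl)amino on a sulfonyl sulfur. Like compound 1, compound 3 has carbon rather than nitrogen on that sulfur, which is a thin basis of one pair. Part of the way back towards compound 1 at 30000 nM is therefore expected, meaning a higher number in this assay. The expected step is a 2.4-fold higher number from compound 2 to compound 3 (0.38 log units; beyond the scatter). For compound 3 the estimate is 12000 nM, with an expected range from 3000 nM to 40000 nM.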

Compound 3, half-maximal inhibitory concentration: 750 nM
The estimate for compound 3 lay 16-fold (1.20 log units) above the measured number; measured number below the stated range.
By their numbers in this assay, from the lowest: compound 3; then compound 2; then compound 1.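

In this assay, the change brings a 6.7-fold lower number from compound 2 to compound 3 (0.82 log units; beyond the scatter), so carbon on the sulfonyl sulfur does not in itself give a higher number, as compound 1 alone had suggested. The two carbon-linked groups instead fall at opposite ends of the series, with a 40-fold lower number from compound 1 to compound 3 (1.60 log units; beyond the scatter), and since 4-methylphenyl and 4-fluorobenzyl both lack the hydrogen-bond donor of (4-fluorophenyl)amino, having no donor at this place does not set the number either. Nothing measured here accounts for these steps.

Going from 4-fluorobenzyl to 4-methylphenyl changes both the carbon link to the ring and the group on the ring, so the compounds shown cannot say which of the two matters. On these data alone, it also remains open how this place would respond to a plain methyl, a longer alkyl chain, or a ring carrying an amine or a carboxylic acid.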